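A few compounds are considered here, and "the series" means these few. Any claim that something is new, unique, unknown or untested is made for them only; others in the source may bear on it.

Notes on the series. Within the data shown here, compound 2, `O=C(NC[C@@H]1CCCc2cc(S(=O)(=O)c3cccc(F)c3)ccc21)c1ncc[nH]1`, is the higher of the two numbers measured so far in an assay on isolated protein for displacement of a labelled ligand from 5-hydroxytryptamine receptor 6 (Homo sapiens) (a lower number here means a stronger inhibitor, a higher number a weaker inhibitor), where compound 2 gives 15.9 nM. Among the measured compounds shown here, its nearest neighbour is compound 1, `NC[C@@H]1CCCc2cc(S(=O)(=O)c3cc(F)cc4[nH]cnc34)ccc21`, which in this assay gives 5.01 nM; the gap between the two lies beyond the usual scatter, and no single-point step connects them.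

The next compound, compound 3, `CN(C[C@@H]1CCCc2cc(S(=O)(=O)c3cccc(F)c3)ccc21)S(C)(=O)=O`, has not yet been measured. The change from compound 2 to compound 3 is methyl(methylsulfonyl)amino in place of ((1H-imidazol-2-yl)carbonyl)amino on a saturated chain carbon bound to a saturated ring carbon. The group that leaves carries two hydrogen-bond donors; the group that enters carries none, and no ring.

For the measured compounds named here, no measured step informs on this change, so the expectation rests on the structures alone. In this assay compound 3 is expected to give 40 nM, within a range of 10 nM to 160 nM. The step this implies, a 2.5-fold higher number from compound 2 to compound 3 (0.40 log units; beyond the scatter), is expected to be a modest weakening, near the edge of the scatter.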

Compound 3, inhibition constant: 0.398 nM
Beside the measured number, compound 3's estimate is 100-fold (2.00 log units) above it; measured number outside the range, below it.
By their numbers in this assay, from the lowest: compound 3; then compound 1; then compound 2.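

Among these compounds, the step of a 40-fold lower number from compound 2 to compound 3 (1.60 log units; beyond the scatter) in this assay is large and beyond the scatter, and it is the first reading of a change at this place, on a saturated chain carbon bound to a saturated ring carbon. It shows that neither the five-membered aromatic ring nor the hydrogen-bond donors of ((1H-imidazol-2-yl)carbonyl)amino are required for a low number here, since methyl(methylsulfonyl)amino has neither. Nothing available accounts for the size of this step.

The compounds shown leave open whether the methyl on the nitrogen or the methylsulfonyl carries the step; a methylsulfonylamino group without that methyl, or an acetyl group in place of the methylsulfonyl, would separate the two. Compound 1 differs from compound 3 in more than one place, so the effect of a plain amine on the core of compound 3 also remains unread.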